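The source may hold more compounds than are shown below. What is called first, only, known or untested is meant among the compounds shown, and "the series" means these compounds.

Of the compounds shown here, two have been tested so far in a physicochemical assay for solubility, read by spectrophotometry, measured as kinetic solubility, at pH 8, tested at 500 uM; a higher number here means a more soluble compound, a lower number a less soluble compound. Compound 1 `Cn1cc(CNS(=O)(=O)c2ccccc2Nc2cc(-c3ccc4ccn(C)c4c3)c3nccnc3c2)cn1` gives 2 ug/mL, and compound 2 `Cn1cc(NC(=O)c2ccncc2Nc2cc(-c3ccc4ccn(C)c4c3)c3nccnc3c2)cn1` gives 2 ug/mL, which places compound 2 level with compound 1, within the scatter. Compound 3 `CN1CC(NC(=O)c2ccncc2Nc2cc(-c3ccc4ccn(C)c4c3)c3nccnc3c2)CCC1=O` matches compound 2 except at one place, where 1-methyl-6-oxopiperidin-3-yl stands in place of 1-methyl-1H-pyrazol-4-yl on an amide-type nitrogen: 1-methyl-6-oxopiperidin-3-yl in place of 1-methyl-1H-pyrazol-4-yl on an amide-type nitrogen. Among the measured compounds shown here, no two measured compounds differ in one place only, so the data give no direct measure of what this change does. The expectation therefore remains a judgement, and a result within the scatter of compound 2 would not be surprising. In this assay the expected step is a 3.5-fold higher number from compound 2 to compound 3 (0.54 log units; beyond the scatter), a modest rise. For compound 3 the estimated value is 7 ug/mL, with an expected range from 2 ug/mL to 30 ug/mL.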

Compound 3, solubility: 253 ug/mL
For compound 3 the middle estimate is 36-fold (1.56 log units) below the measured one; measured number above the stated range.
By their numbers in this assay, from the lowest: compounds 1 and 2 (each within the scatter of the next); then compound 3.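

Putting 1-methyl-6-oxopiperidin-3-yl in place of 1-methyl-1H-pyrazol-4-yl on an amide-type nitrogen gives a 130-fold higher number from compound 2 to compound 3 (2.10 log units; beyond the scatter) in this assay, so this one place can by itself move the read-out far beyond the scatter while the rest of the molecule stays the same. The change replaces a five-membered aromatic ring with a six-membered non-aromatic ring that carries a double bond outside aromatic rings, and neither group has a net charge. Nothing measured here ties the step to any one of these differences.

The compounds shown leave open whether the ring carbonyl matters or whether the non-aromatic ring alone would give such a step, as a plain cyclohexyl group could show. They also leave open whether the same replacement would act similarly in the sulfonamide series of compound 1.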